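This account rests on a few compounds, and the source may have more. Where it says the series, first, only, none or still open, it means among the compounds named here.

The measured compounds and their numbers:

Compound 1 `COc1ccc2nc(C)cc(OCC(=O)Nc3cc(C)cc(C)c3)c2c1` gives 26000 nM in a physicochemical assay for solubility, in phosphate buffer, measured as kinetic solubility, with a stated time of 1 h, at pH 7.4; on this read-out higher numbers stand for higher solubility and lower numbers for lower solubility.
Compound 2 `Cc1cc(C)cc(NC(=O)COc2cc(C)nc3ccccc23)c1` gives 55000 nM in this assay.
Compound 3 `CCCc1cc(OCC(=O)Nc2cc(C)cc(C)c2)c2cc(OC)ccc2n1` gives 12000 nM in this assay.

Among these three, compound 1 stands second highest. Its nearest neighbour is compound 2, reached by a hydrogen in place of methoxy on an aromatic carbon, a change that gave a 2.1-fold higher number from compound 1 to compound 2 (0.33 log units; beyond the scatter). Furthest away is compound 3, reached by ethyl in place of hydrogen on a saturated chain carbon bound to an aromatic carbon, which gave a 2.2-fold lower number from compound 1 to compound 3 (0.34 log units; beyond the scatter). Both measured steps are therefore of modest size and both alter the shared core of compound 1, not the ring on the amide nitrogen.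

Compound 4 `COc1cccc(NC(=O)COc2cc(C)nc3ccc(OC)cc23)c1` differs from compound 1 by 3-methoxyphenyl in place of 3,5-dimethylphenyl on an amide-type nitrogen. Within the data shown here, no measured step touches this part of the molecule, so neither of the two steps above bears directly on it; they only show that single changes have so far moved solubility by modest amounts in either direction. For compound 4 the expected outcome is thus a number close to that of compound 1, with a step of a 1.2-fold higher number from compound 1 to compound 4 (0.06 log units; within the scatter) in this assay and no direction that the data can support beyond the scatter. Compound 4 is estimated at 30000 nM, with a plausible range from 12000 nM to 75000 nM.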

Compound 4, solubility: 35000 nM
For compound 4 the middle estimate is 1.2-fold (0.07 log units) below the measured one; low and high end bracket the measured number.
By their numbers in this assay, from the lowest: compound 3; then compounds 1, 4 and 2 (each within the scatter of the next, the first and the last beyond it).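

In this assay, the first step read at the ring on the amide-type nitrogen, 3-methoxyphenyl in place of 3,5-dimethylphenyl, gave a 1.3-fold higher number from compound 1 to compound 4 (0.13 log units; within the scatter). This exchange keeps the heavy-atom count at 8 and a six-membered aromatic ring of carbon only, and it brings in 1 hydrogen-bond acceptor where the group that leaves has 0, yet the number stays within the scatter, unlike the two earlier changes elsewhere on the shared core, which gave a 2.1-fold higher number from compound 1 to compound 2 (0.33 log units; beyond the scatter) and a 2.2-fold lower number from compound 1 to compound 3 (0.34 log units; beyond the scatter). Nothing in the material at hand gives a measured reason for this result.

The compounds shown offer a single replacement at this position, so they leave open whether the ring on the amide-type nitrogen tolerates change in general or only this particular exchange, and whether a carboxylic acid or an amine on that ring would move the number beyond the scatter. They also leave open whether the step would stay the same size on the cores of compound 2 or compound 3, which carry the 3,5-dimethylphenyl group.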